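A few compounds are considered here, and "the series" means these few. Any claim that something is new, unique, unknown or untested is made for them only; others in the source may bear on it.

Measured so far:
compound 1 `CCC/C=C/C(=O)N(Cc1ccc(OC)c(O)c1)c1cc(OC)c(OC)c(OC)c1`: 70 nM in a functional assay on MGC-803 cells (Homo sapiens) for inhibition, read by MTT assay, with a stated time of 48 h; a higher number here means a weaker inhibitor, a lower number a stronger inhibitor
compound 2 `COc1ccc(CNc2cc(OC)c(OC)c(OC)c2)cc1C`: 56800 nM
compound 3 `COc1ccc(CNc2cc(OC)c(OC)c(OC)c2)cc1N`: 7970 nM

Compound 1 gives the lowest number of the three; compound 3 is the nearest and compound 2 the furthest. The unmeasured compound 4 `COc1ccc(CN(C(=O)CO)c2cc(OC)c(OC)c(OC)c2)cc1O` differs from compound 1 in one place: hydroxymethyl in place of pent-1-en-1-yl on a carbonyl carbon. Among the measured compounds shown here, the only measured step, a 7.1-fold lower number from compound 2 to compound 3 (0.85 log units; beyond the scatter), changes a substituent on the other aromatic ring and so does not bear directly on this change. Compounds 2 and 3 carry no acyl group at all and give far higher numbers than compound 1, which hints that the carbonyl side chain matters. A rise in this assay is therefore expected for compound 4, estimated at 600 nM (range 120 nM to 3500 nM), a step of an 8.6-fold higher number from compound 1 to compound 4 (0.93 log units; beyond the scatter).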

Compound 4, half-maximal inhibitory concentration: 160 nM
Estimate against measurement, compound 4: 3.8-fold (0.57 log units) above; low and high end bracket the measured number.
By their numbers in this assay, from the lowest: compound 1; then compound 4; then compound 3; then compound 2.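

In this assay the swap of pent-1-en-1-yl for hydroxymethyl on the carbonyl carbon gives a 2.3-fold higher number from compound 1 to compound 4 (0.36 log units; beyond the scatter) and so counts as a modest change. The long chain with its double bond is therefore not essential for a low number at this position, and a much shorter chain bearing a hydroxyl group largely keeps it. No measurement shown explains this step. Length, the double bond and the hydroxyl group all change at once, so their shares cannot be separated. As far as these compounds go, how an aminomethyl group or a saturated pentyl chain would fare here remains open.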